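Adding carboxy to the tert-butyl amide of compound 3

The source may report more compounds than this note shows. Statements on the series, on what has been measured and on what is new or still open speak of the compounds shown alone.

- compound 1 `CSCC(=O)N1CCSC1COc1ccccc1O` gives 28 mg/kg as its value
- compound 2 `COc1ccccc1OCC1N(C(=O)CS(C)(=O)=O)CC[S+]1[O-]` gives 28 mg/kg as its value
- compound 3 `COc1ccccc1OCC1SCCN1C(=O)C(C)(C)C` gives 24 mg/kg as its value

All three values come from a functional assay on the whole organism (trachea) for inhibition, with Cavia porcellus as the target (a higher number here means that more compound is needed for the effect, a lower number that less compound is needed), and lie within the scatter of one another. Compound 3 at 24 mg/kg therefore stands level with compound 1 and compound 2 on these numbers.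

The change to compound 4 `COc1ccccc1OCC1SCCN1C(=O)C(C)(C)C(=O)O` is carboxy in place of methyl on a saturated chain carbon bound to a carbonyl carbon and two saturated chain carbons and places carboxy in place of methyl on a saturated chain carbon bound to a carbonyl carbon and two saturated chain carbons. This turns tert-butyl into 1-carboxy-1-methylethyl.

Going by the values given here, no measured pair isolates this change. Compound 2 at 28 mg/kg differs from compound 3 in more than one place and still lies within the scatter of it, so only a modest shift is expected. The estimated step of a 1.3-fold higher number from compound 3 to compound 4 (0.12 log units; within the scatter) points to a slightly higher number in this assay and is expected to stay within the scatter. Compound 4 is estimated at 32 mg/kg with an expected range from 12 mg/kg to 85 mg/kg in this assay once measured.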

Compound 4, dose for half-maximal effect: 21 mg/kg
Estimate against measurement, compound 4: 1.5-fold (0.18 log units) above; the range from low to high includes it.
By their numbers in this assay, from the lowest: compounds 4, 3, 1 and 2 (each within the scatter of the next).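

In this assay, going by these compounds alone, the replacement of methyl by carboxy on a saturated chain carbon bound to a carbonyl carbon and two saturated chain carbons gives a 1.1-fold lower number from compound 3 to compound 4 (0.06 log units; within the scatter) and is the only change here read in a single place. At this position, then, tert-butyl and 1-carboxy-1-methylethyl stand level, and the added carboxy, with its hydrogen-bond donor and acceptor, brings no step beyond the scatter. No measurement shown here accounts for this result.

From the compounds shown here alone, whether a methyl ester, a primary amide or an amine on the same carbon would also stay level with compound 3 remains open. Also open, going by these compounds, is whether a longer chain ending in a carboxylic acid would hold this level.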